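A Longer Chain and Tolerance in Vero Cells

The source may report more compounds than this note shows. Statements on the series, on what has been measured and on what is new or still open speak of the compounds shown alone.

Measured compounds:
Compound 1, `CCCCCCCNc1nccnc1C(=O)NCc1ccccc1`: > 100000 nM
Compound 2, `CCCCNc1cncc(C(=O)NCc2ccccc2)n1`: 100000 nM

Both compounds were tested in an ADME assay on Vero cells (Chlorocebus sabaeus) for cytotoxicity, read by microscopy, with a stated time of 6 days; on this read-out lower numbers stand for higher toxicity in this test and higher numbers for lower toxicity in this test. Compound 1 gives > 100000 nM, which is a limit of the test rather than a number, and it sits at the limit of > 100000 nM in this assay, at which 1 of the 2 values shown sits. Among the compounds with values here, compound 2 gives 100000 nM, the only number among the two results, so there is no ordering to draw between them.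

Compound 3, `CCCCCNc1cncc(C(=O)NCc2ccccc2)n1`, is not yet measured. It differs from compound 2 by methyl in place of hydrogen on a saturated chain carbon, four bonds along the chain from a nitrogen on an aromatic ring. Within the data shown here, no step between two measured compounds follows this kind of change, so no measured guide exists for it. The expectation is a step of no size beyond the usual scatter, in either direction, no change at the digits printed from compound 2 to compound 3 (within the scatter). Compound 3 is therefore expected to give about 100000 nM in this assay, with a range from 50000 nM to 200000 nM, and a fair chance that only a limit is reported.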

Compound 3, minimum cytotoxic concentration: > 100000 nM
Compound 3: only a limit was reported; the forecaster's own chance of this, stated with the estimate: 40%; the middle value sits exactly at the limit.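

In this assay, within the data shown here, the change of hydrogen to methyl on the chain gives a number no lower from compound 2 to compound 3 (the limit leaves the size open) and this is the first step between two measured compounds that can be followed here. The result for compound 3 is a limit of the test, not a number. At this place, four bonds along the chain from a nitrogen on an aromatic ring, the added methyl brought no lower reading, and most values shown now sit at the top of what the test reports: the limit of > 100000 nM in this assay, at which 2 of the 3 values shown sit.

From the compounds shown here alone, the size of the step stays open, and so does the question of whether any change at this place would bring a measurable toxic concentration. A longer chain, or an amine or a carboxylic acid in place of the methyl, could show how far this tolerance in the cells extends.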